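Chain-end amides in the series: the next step

The source may hold more compounds than are shown below. What is called first, only, known or untested is meant among the compounds shown, and "the series" means these compounds.

In an ADME assay on CEM-SS cells (Homo sapiens) for cytotoxicity, read by XTT assay, with a stated time of 6 days (on this read-out lower numbers stand for higher toxicity in this test and higher numbers for lower toxicity in this test), compound 1 (`CCCC(=O)OCSc1ccccc1C(=O)NCCC(N)=O`) gives > 100 uM, which is a limit of the assay and not a number. Within the data shown here, compound 2 (`CCCC(=O)OCSc1ccccc1C(=O)NCCCCCC(N)=O`) gives 16.3 uM and compound 3 (`CCCC(=O)OCSc1ccccc1C(=O)NCCCCCCC(N)=O`) gives 10.4 uM, so compound 3 stands within the scatter of its only numerical neighbour, as a 1.6-fold lower number from compound 2 to compound 3 (0.20 log units; within the scatter) shows. Compound 4 (`CCCC(=O)OCSc1ccccc1C(=O)NCCCNC(C)=O`) carries a smaller chain end: acetamido in place of 3-carbamoylpropyl on a saturated chain carbon, three bonds along the chain from an amide-type nitrogen. The bearing steps are an at least 6.1-fold lower number from compound 1 to compound 2 (0.78 log units; beyond the scatter) and an at least 9.6-fold lower number from compound 1 to compound 3 (0.98 log units; beyond the scatter), both beyond the scatter, and the new change is read as running partly back against them. A higher number, beyond the scatter, is therefore expected in this assay, with an estimated 3.8-fold higher number from compound 3 to compound 4 (0.59 log units; beyond the scatter). The estimate for compound 4 is 40 uM, with an expected range of 17 uM to 95 uM.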

Compound 4, half-maximal toxic concentration: 21.1 uM
Compound 4: the middle estimate sits 1.9-fold (0.28 log units) above what was measured, within the range that was stated.
By their numbers in this assay, from the lowest: compounds 3, 2 and 4 (each within the scatter of the next, the first and the last beyond it). At a limit, above all of these: compound 1.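

In this assay, acetamido in place of 3-carbamoylpropyl, three bonds along the chain from an amide-type nitrogen, gives a 2.0-fold higher number from compound 3 to compound 4 (0.31 log units; beyond the scatter), while acetamido in place of 2-carbamoylethyl gives a 1.3-fold higher number from compound 2 to compound 4 (0.11 log units; within the scatter). Acetamidomethyl in place of carbamoyl still leaves an at least 4.7-fold lower number from compound 1 to compound 4 (0.67 log units; beyond the scatter), so this chain end does not return the series to the reading of compound 1. The reading of compound 1 is a limit and not a number: the limit of > 100 uM in this assay, at which 1 of the 4 values shown sits.

As far as these compounds go, how an amine or a carboxylic acid at this chain end would read in this assay stays open. So does whether a longer chain ending in acetamido would track the carbamoyl chains.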